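The source may hold more compounds than are shown below. What is called first, only, known or untested is meant among the compounds shown, and "the series" means these compounds.

Measured compounds:
- compound 1, `COc1ccc2cc(C(C)c3nnc4n3N=C(c3ccc(Cl)cc3Cl)CS4)ccc2c1`: 14000 nM
- compound 2, `COc1ccc(C2=Nn3c(nnc3C(C)c3ccc(-c4ccccc4)c(F)c3)SC2)cc1`: 4400 nM
- compound 3, `COc1ccc2cc(C(C)c3nnc4n3N=C(c3ccc(C(F)(F)F)cc3)CS4)ccc2c1`: 10800 nM

In a functional assay on HCT-116 cells (Homo sapiens) for inhibition, read by sulforhodamine B assay, with a stated time of 72 h (a higher number here means a weaker inhibitor, a lower number a stronger inhibitor), compound 2 gives the lowest number of the three, and its gaps to compound 3 and to compound 1 both lie beyond the usual scatter, so among these it is the strongest inhibitor. Compound 4, `CC(c1ccc(-c2ccccc2)c(F)c1)c1nnc2n1N=C(c1ccc([N+](=O)[O-])cc1)CS2`, keeps the rest of compound 2 and changes one group: nitro in place of methoxy on an aromatic carbon. Within the data shown here, the only measured step that touches the same part of the molecule is the one from compound 1 to compound 3, which also swaps the aromatic ring on the carbon doubly bonded to nitrogen; there a 1.3-fold lower number from compound 1 to compound 3 (0.11 log units; within the scatter). That precedent is small, so a change on this ring is not expected to move the number beyond the scatter in this assay, in either direction. For compound 4 the expected result is therefore 5000 nM, within a range from 1500 nM to 16000 nM, which means an expected step of a 1.1-fold higher number from compound 2 to compound 4 (0.06 log units; within the scatter). Among the measured compounds shown here, compound 4 is estimated to remain close to compound 2, with the range kept wide since only one comparable step is available.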

Compound 4, half-maximal inhibitory concentration: 7100 nM
For compound 4 the middle estimate is 1.4-fold (0.15 log units) below the measured one; low and high end bracket the measured number.
By their numbers in this assay, from the lowest: compounds 2, 4, 3 and 1 (each within the scatter of the next, the first and the last beyond it).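

In this assay, nitro in place of methoxy gives a 1.6-fold higher number from compound 2 to compound 4 (0.21 log units; within the scatter), so this para position on the ring keeps the number within the scatter even when one group is exchanged for another with different atoms. The earlier step at this ring, a 1.3-fold lower number from compound 1 to compound 3 (0.11 log units; within the scatter), changed a dichlorophenyl to a 4-(trifluoromethyl)phenyl on the other remainder of the molecule, so compound 4 adds a second case, on a second remainder, in which a ring change stays within the scatter. Nothing available here accounts for this small step.

Going by these compounds, it remains open whether an amine or a carboxylic acid at this position would also stay within the scatter. Also open, on these data alone, is whether a step from 4-methoxyphenyl to 4-nitrophenyl would read the same on the remainder carried by compound 3.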